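Difluoromethyl carbonyl for ethylcarbamoyl: a solubility expectation

A few compounds are considered here, and "the series" means these few. Any claim that something is new, unique, unknown or untested is made for them only; others in the source may bear on it.

Compound 1 `O=C1CCC(=O)N1C[C@H]1CN(c2ccc(-n3cc(-c4ccccn4)cn3)c(F)c2)C(=O)O1` in a physicochemical assay for solubility, read by HPLC, with a stated time of 24 h; on this read-out lower numbers stand for lower solubility and higher numbers for higher solubility: 45300 nM
Compound 2 `CCNC(=O)NC[C@H]1CN(c2ccc(-n3cc(-c4ccccn4)cn3)c(F)c2)C(=O)O1` in this assay: 222000 nM

Of these two numbers compound 2 holds the higher one, compound 1 the lower. Compound 3 `O=C(NC[C@H]1CN(c2ccc(-n3cc(-c4ccccn4)cn3)c(F)c2)C(=O)O1)C(F)F` differs from compound 2 by difluoromethyl in place of ethylamino on a carbonyl carbon. For the measured compounds named here, the one measured step, a 4.9-fold higher number from compound 1 to compound 2 (0.69 log units; beyond the scatter), changes a different group at a different place, so it bears on this change only loosely. With the hydrogen-bond donor of the ethylamino group gone, compound 3 is expected to give a modestly lower number, by a 2.8-fold lower number from compound 2 to compound 3 (0.44 log units; beyond the scatter). Compound 3 is therefore estimated at 80000 nM, within 25000 nM to 250000 nM.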

Compound 3, solubility: 29900 nM
Compound 3: the middle estimate sits 2.7-fold (0.43 log units) above what was measured, and the stated range covers the measured number.
By their numbers in this assay, from the lowest: compounds 3 and 1 (each within the scatter of the next); then compound 2.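

In this assay, difluoromethyl in place of ethylamino on this carbonyl carbon gives a 7.4-fold lower number from compound 2 to compound 3 (0.87 log units; beyond the scatter), so the group on this carbon matters to the read-out. The further step, a 1.5-fold lower number from compound 1 to compound 3 (0.18 log units; within the scatter), lies within the scatter, leaving ((difluoromethyl)carbonyl)amino and 2,5-dioxopyrrolidin-1-yl untold apart. No measurement shown gives a reason for either step. Left open is how a methyl, a methylamino group or a longer alkylamino chain on this carbonyl carbon would read, and so whether the change follows the loss of the ethylamino nitrogen or the arrival of fluorine.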